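Carbamoyl for Methyl on the Piperidine Amide

The source may hold more compounds than are shown below. What is called first, only, known or untested is meant among the compounds shown, and "the series" means these compounds.

Compound 1 `CC1CCCN(C(=O)CN2CN(c3ccccc3)C3(CCN(C(=O)c4ccc(C5CCCCC5)cc4)CC3)C2=O)C1`: 3600 nM
Compound 2 `CC1CCCN(C(=O)CN2CN(c3ccccc3)C3(CCN(C(=O)c4ccc(C(C)(C)C)cc4)CC3)C2=O)C1`: 12000 nM
Compound 3 `CC(C)(C)OC(=O)N1CCN(C(=O)CN2CN(c3ccccc3)C3(CCN(C(=O)c4ccc(C5CCCCC5)cc4)CC3)C2=O)CC1`: 3500 nM

Of the compounds shown here, three built on the same core have been tested in an assay on HEK293 cells for displacement of a labelled ligand from NPC1-like intracellular cholesterol transporter 1 (Homo sapiens); on this read-out lower numbers stand for stronger inhibition and higher numbers for weaker inhibition. Compound 2 gives 12000 nM, the highest of the three numbers. The nearest neighbour is compound 1, and the difference between the two is a modest one: a 3.3-fold higher number from compound 1 to compound 2 (0.52 log units; beyond the scatter). Compound 3 lies furthest from compound 2, although the gap is of similar size.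

The unmeasured compound 4 `CC(C)(C)c1ccc(C(=O)N2CCC3(CC2)C(=O)N(CC(=O)N2CCCC(C(N)=O)C2)CN3c2ccccc2)cc1` keeps the tert-butyl end of compound 2 and alters the other end of the molecule: carbamoyl in place of methyl on a saturated ring carbon.

Among the measured compounds shown here, no measured step touches this piperidine position, so nothing speaks directly to the change. The only hint comes from the other end of the core: compound 1 gives 3600 nM and compound 3 gives 3500 nM, and these two numbers fall within the scatter of each other even though the amide attached to the glycine differs between them. That suggests this part of the molecule tolerates variation, but it rests on a single pair.

The expected step is no change at the digits printed from compound 2 to compound 4 (within the scatter), that is, nothing beyond the scatter. For compound 4 the estimated value is 12000 nM, with a likely range from 4000 nM to 36000 nM.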

Compound 4, half-maximal inhibitory concentration: 16900 nM
Compound 4: the middle estimate sits 1.4-fold (0.15 log units) below what was measured, and the stated range covers the measured number.
By their numbers in this assay, from the lowest: compounds 3 and 1 (each within the scatter of the next); then compounds 2 and 4 (each within the scatter of the next).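

Among the compounds shown here, this is the first measured change at this position, on a saturated ring carbon two ring bonds from the ring nitrogen, and it reads as no real shift in this assay (a 1.4-fold higher number from compound 2 to compound 4 (0.15 log units; within the scatter)). Carbamoyl brings a hydrogen-bond donor and a hydrogen-bond acceptor that methyl does not have, yet with the tert-butyl group held constant, the swap makes no difference that can be told from the usual spread of repeat measurements. The earlier compounds could only hint at tolerance in this part of the molecule, since compound 1 and compound 3 differ by a whole amide group rather than by one substituent on this ring, and no measurement available here explains the result.

On these data alone, whether a carboxylic acid, an amine or a longer chain on the same ring carbon would also leave the number in place remains open. So does whether carbamoyl would behave the same way in a compound carrying the cyclohexyl group of compound 1, whose number is lower than that of compound 2.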